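Replacing isopropyl with cyclohexyl: a second test

This account rests on a few compounds, and the source may have more. Where it says the series, first, only, none or still open, it means among the compounds named here.

The measured compounds, in a functional assay on NB-4 cells (Homo sapiens) for inhibition, read by XTT assay, with a stated time of 48 h; on this read-out higher numbers stand for weaker inhibition and lower numbers for stronger inhibition:
Compound 1 `COc1ccc(C(=O)/C(=C/c2ccc(Cl)cc2Cl)CC(C)C)cc1` gives 14600 nM.
Compound 2 `COc1ccc(C(=O)/C(=C/c2ccc(C(F)(F)F)cc2)CC(C)C)cc1` gives 12600 nM.
Compound 3 `COc1ccc(C(=O)/C(=C/c2ccc(Cl)cc2Cl)CC2CCCCC2)cc1` gives 48900 nM.

Compound 1 and compound 2 share the same change in one place, but the difference between their two cores is not broken down here. Their values in this assay lie within the scatter of each other, so nothing is said about their order.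

Compound 3 is compound 1 with the change (cyclohexyl in place of isopropyl on a saturated chain carbon bound to a double-bonded chain carbon). This gave a 3.3-fold higher number from compound 1 to compound 3 (0.52 log units; beyond the scatter) in this assay.

Compound 4 `COc1ccc(C(=O)/C(=C/c2ccc(C(F)(F)F)cc2)CC2CCCCC2)cc1` is not yet measured. It is compound 2 with the change (cyclohexyl in place of isopropyl on a saturated chain carbon bound to a double-bonded chain carbon), the same change as from compound 1 to compound 3, made at the same place. Among the compounds here this change occurs twice, and only one of the two is measured.

Because compound 1 to compound 3 gave a 3.3-fold higher number from compound 1 to compound 3 (0.52 log units; beyond the scatter), the same change on compound 2 is expected to give a step of a similar size, a 3.2-fold higher number from compound 2 to compound 4 (0.50 log units; beyond the scatter) in this assay. This rests on a single measured pair, so the range is kept wide. Compound 4 is therefore estimated at 40000 nM, with the interval 18000 nM to 90000 nM in this assay.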

Compound 4, half-maximal inhibitory concentration: 18200 nM
Compound 4: the middle estimate sits 2.2-fold (0.34 log units) above what was measured, within the range that was stated.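

Carried to the second core, cyclohexyl in place of isopropyl gave a 1.4-fold higher number from compound 2 to compound 4 (0.16 log units; within the scatter) in this assay, while on the first core the same change gave a 3.3-fold higher number from compound 1 to compound 3 (0.52 log units; beyond the scatter). The first step lies beyond the scatter and the second within it, yet the two steps themselves cannot be said to differ: the same change on two cores in this assay, a 3.3-fold higher number (0.52 log units; beyond the scatter) from compound 1 to compound 3 and a 1.4-fold higher number (0.16 log units; within the scatter) from compound 2 to compound 4, 2.3-fold (0.37 log units) apart, within the scatter of two such steps. For the compounds shown here, the pairs therefore fit a change that carries over from one core to the other, and they equally fit one that has a clear effect on only one core, so they do not show that the step can be transferred at a fixed size, and two pairs in one assay cannot settle the matter.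

What the compounds shown leave open is how other groups at this place on a saturated chain carbon bound to a double-bonded chain carbon would behave, for example a cyclopentyl ring, a phenyl ring, a longer straight chain, or a chain ending in an amine or a carboxylic acid. From the compounds shown here alone, it also remains open whether the change would give a step of similar size on further cores, such as one carrying a nitrile in place of the trifluoromethyl group.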